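The source may hold more compounds than are shown below. What is called first, only, known or untested is meant among the compounds shown, and "the series" means these compounds.

Compound 3 `COC(=O)C1=C(C)N=C(C)/C(=C(/O)OC)C1c1cccc(NC(=O)NCCNC2CCN(c3ccccc3[N+](=O)[O-])CC2)c1` gives 2 nM in an assay on SK-N-MC cells for inhibition of Neuropeptide Y receptor type 1 (Homo sapiens) (on this read-out higher numbers stand for weaker inhibition and lower numbers for stronger inhibition), the lowest of the three numbers, though its gaps to compound 2 and compound 1 both lie within the scatter. Compound 4 `COC(=O)C1=C(C)N=C(C)/C(=C(/O)OC)C1c1cccc(NC(=O)NCCNC2CCN(c3ccccc3SC)CC2)c1` differs by methylsulfanyl in place of nitro on an aromatic carbon, placed ortho to a large group. Among the compounds with values here, no measured pair carries this exact change; the closest is the step of a 1.3-fold lower number from compound 1 to compound 2 (0.12 log units; within the scatter), which was within the scatter, with compound 1 `COC(=O)C1=C(C)N=C(C)/C(=C(/O)OC)C1c1cccc(N/C(=N/CCNC2CCN(c3ccccc3C)CC2)NC#N)c1` giving 4 nM and compound 2 `COC(=O)C1=C(C)N=C(C)/C(=C(/O)OC)C1c1cccc(N/C(=N/CCNC2CCN(c3ccccc3SC)CC2)NC#N)c1` giving 3 nM in this assay. Compound 2 already carries methylsulfanyl at that place with a low number. Compound 4 is therefore expected to show a 1.5-fold higher number from compound 3 to compound 4 (0.18 log units; within the scatter), nothing beyond the scatter, and its estimated value is 3 nM, with a range from 1 nM to 9 nM.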

Compound 4, half-maximal inhibitory concentration: 5 nM
The estimate for compound 4 lay 1.7-fold (0.22 log units) below the measured number, within the range that was stated.
By their numbers in this assay, from the lowest: compounds 3, 2, 1 and 4 (each within the scatter of the next, the first and the last beyond it).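

Replacing nitro with methylsulfanyl on this aromatic carbon, ortho to a large group, gives a 2.5-fold higher number from compound 3 to compound 4 (0.40 log units; beyond the scatter) in this assay. This place therefore responds to a change of group beyond the scatter, which the earlier step, a 1.3-fold lower number from compound 1 to compound 2 (0.12 log units; within the scatter), did not show, although compound 4 still gives a low number of 5 nM. Nothing in the data given accounts for this shift.

Going by these compounds, whether an amine, a carboxylic acid or a methoxy group at this place would hold the number near that of compound 3 stays open. Also open, on these data alone, is whether nitro and methylsulfanyl would differ in the same way on the rest of compound 1.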